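A few compounds are considered here, and "the series" means these few. Any claim that something is new, unique, unknown or untested is made for them only; others in the source may bear on it.

Measured compounds:
- compound 1, `CC(C)(Oc1ccc(NCc2cccc(Oc3ccccc3)c2)cc1)C(=O)O`: 14%
- compound 2, `Cc1nc(-c2ccc(C(F)(F)F)cc2)sc1CNc1ccc(C(C)CC(=O)O)cc1`: 109%

In a functional assay on CHO cells for agonist activity at Free fatty acid receptor 1 (Homo sapiens), read by a luciferase reporter (a lower number here means a smaller maximal response, a higher number a larger maximal response), compound 1 gives 14%. Among the compounds with values here, that is the lower of the two numbers known; the only other measured compound, compound 2, gives 109% in this assay, a difference that lies well beyond the usual scatter. The two compounds share no single-point relationship, so their values stand side by side without a counted step between them.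

Compound 3, `O=C(CCc1ccc(NCc2cccc(Oc3ccccc3)c2)cc1)N1CCCC1`, has not yet been measured in this assay. It differs from compound 1 in one place: 2-((pyrrolidin-1-yl)carbonyl)ethyl in place of 1-carboxy-1-methylethoxy on an aromatic carbon. Within the data shown here, no pair of measured compounds shows this change, so there is no direct precedent for its effect on the maximal response.

Given that compound 1 already sits low in this assay, the step from compound 1 to compound 3 is expected to be a number 4 percentage points lower from compound 1 to compound 3 (within the scatter), most likely none beyond the scatter or a small decrease. On that basis, compound 3 is expected to give about 10% in this assay, within a range from 0% to 35%.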

Compound 3, largest response reached (reported as percent of maximum), in percent of the reference or control that the assay uses: 46%
For compound 3 the middle estimate is 36 percentage points below the measured one, outside the stated range (above it).
By their numbers in this assay, from the lowest: compound 1; then compound 3; then compound 2.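

In this assay, putting 2-((pyrrolidin-1-yl)carbonyl)ethyl in place of 1-carboxy-1-methylethoxy on this aromatic carbon, para to a large group, gives a number 32 percentage points higher from compound 1 to compound 3 (beyond the scatter) on the otherwise unchanged core. The step shows that this position has a clear influence on the maximal response, and that within this pair the response does not depend on the carboxy group: compound 3 carries none and still gives 46% in this assay, with no hydrogen-bond donor in the entering group. Nothing measured on either group explains the rise.

With both the group's end and its link to the aromatic carbon changing in a single step, the compounds shown leave open which part of the change accounts for the higher response. A 2-carboxyethyl group at this place would separate the effect of the link from that of the end group, while an open-chain diethylamide or a piperidine amide would show whether the pyrrolidine ring itself matters.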